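From a dimethoxyphenyl amide to a chlorophenyl amide

This account rests on a few compounds, and the source may have more. Where it says the series, first, only, none or still open, it means among the compounds named here.

Measured in a functional assay on BXPC-3 cells (Homo sapiens) for inhibition, read by MTT assay; a higher number here means a weaker inhibitor, a lower number a stronger inhibitor:
- Compound 1 `COc1cccc(NC(=O)c2cc3cnc(Nc4ccc(N5CCNCC5)cn4)nc3n2C2CCCC2)c1`: 10500 nM
- Compound 2 `COc1ccc(NC(=O)c2cc3cnc(Nc4ccc(N5CCNCC5)cn4)nc3n2C2CCCC2)cc1`: 8970 nM
- Compound 3 `COc1ccc(NC(=O)c2cc3cnc(Nc4ccc(N5CCNCC5)cn4)nc3n2C2CCCC2)c(OC)c1`: 3650 nM

Compound 3 has the lowest number of the three, and its steps to both others lie beyond the scatter. The next change leads to compound 4 `O=C(Nc1ccccc1Cl)c1cc2cnc(Nc3ccc(N4CCNCC4)cn3)nc2n1C1CCCC1`, with 2-chlorophenyl in place of 2,4-dimethoxyphenyl on an amide-type nitrogen. Among the compounds with values here, three measured steps bear on it. The first, a 1.2-fold lower number from compound 1 to compound 2 (0.07 log units; within the scatter), separates the two compounds with a single methoxy. Within the data shown here, the other two, a 2.5-fold lower number from compound 2 to compound 3 (0.39 log units; beyond the scatter) and a 2.9-fold lower number from compound 1 to compound 3 (0.46 log units; beyond the scatter), are modest and both end at the only compound with two methoxy groups. Among the measured compounds shown here, compound 4 carries no methoxy group, and no measured compound carries chlorine, so the comparison is indirect. A modest move back towards higher numbers is therefore expected in this assay. The expected change is a 2.1-fold higher number from compound 3 to compound 4 (0.31 log units; beyond the scatter). For compound 4 the estimated value is 7500 nM, with an expected range from 3000 nM to 18000 nM.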

Compound 4, half-maximal inhibitory concentration: 4350 nM
The estimate for compound 4 lay 1.7-fold (0.24 log units) above the measured number; measured number inside the range.
By their numbers in this assay, from the lowest: compounds 3 and 4 (each within the scatter of the next); then compounds 2 and 1 (each within the scatter of the next).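

In this assay, 2-chlorophenyl in place of 2,4-dimethoxyphenyl on the amide-type nitrogen gives a 1.2-fold higher number from compound 3 to compound 4 (0.08 log units; within the scatter), so this position tolerates the exchange of both methoxy groups for a chlorine without a step beyond the scatter. The same group also stands apart from the singly substituted methoxyphenyl amides, with a 2.1-fold lower number from compound 2 to compound 4 (0.31 log units; beyond the scatter) and a 2.4-fold lower number from compound 1 to compound 4 (0.38 log units; beyond the scatter), so among these four compounds a second methoxy group is not the only change that gives a modest step towards lower numbers. Nothing measured here bears on the reason for these steps.

Whether the chlorine is needed at all stays open: the compounds shown do not say how plain phenyl would read on this nitrogen, nor a fluorine or a methyl group in place of that chlorine. They also leave open how a saturated ring such as cyclohexyl would read there in place of the aromatic ring.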